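Swapping an anilino group for dipropylamino on a quinone core

This account rests on a few compounds, and the source may have more. Where it says the series, first, only, none or still open, it means among the compounds named here.

Compound 1 `O=C1C=C(Nc2ccc(I)cc2)C(=O)c2c1nc1n2[C@H]2OC[C@@H](O)[C@H]2OC1` and compound 2 `COc1cccc(NC2=CC(=O)c3c(nc4n3[C@H]3OC[C@@H](O)[C@H]3OC4)C2=O)c1` share one core and differ only in the substituent on the amino group. In a functional assay on MCF7 cells (Homo sapiens) for inhibition, read by sulforhodamine B assay (a higher number here means a weaker inhibitor, a lower number a stronger inhibitor), compound 1 gives 2230 nM, the lowest of the two numbers, while compound 2 gives 3830 nM; the two lie within the scatter of each other. Compound 3 `CCCN(CCC)C1=CC(=O)c2nc3n(c2C1=O)[C@H]1OC[C@@H](O)[C@H]1OC3` is not yet measured. It differs from compound 1 in one place: dipropylamino in place of (4-iodophenyl)amino on a double-bonded ring carbon. For the measured compounds named here, with no comparable step measured, a moderate loss is expected, and compound 3 is estimated at 6000 nM, between 1500 nM and 25000 nM, which is the expected step of a 2.7-fold higher number from compound 1 to compound 3 (0.43 log units; beyond the scatter).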

Compound 3, half-maximal inhibitory concentration: > 16000 nM
Compound 3: only a limit was reported (the forecaster's own chance of this, stated with the estimate: 15%); middle value at least 2.6-fold (0.42 log units) from the limit.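

In this assay, dipropylamino in place of (4-iodophenyl)amino gives an at least 7.1-fold higher number from compound 1 to compound 3 (0.85 log units; beyond the scatter). This shows that the double-bonded ring carbon does not tolerate every amino substituent equally: here, losing the aromatic ring and the hydrogen-bond donor together goes with weaker inhibition. The entry for compound 3 is a limit of the assay, not a number: the limit of > 16000 nM in this assay, at which 1 of the 3 values shown sits.

The ring and the donor leave together, so their contributions remain unseparated. Propylamino would keep the donor without the ring, while methyl(phenyl)amino would keep the ring without the donor.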